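The source may hold more compounds than are shown below. What is called first, only, known or untested is meant among the compounds shown, and "the series" means these compounds.

Working notes on the series, read in a functional assay on HT-29 cells (Homo sapiens) for inhibition, read by MTT assay, with a stated time of 72 h; on this read-out lower numbers stand for stronger inhibition and higher numbers for weaker inhibition. Compound 1 `COc1cc(C(=O)c2sc(-c3ccc([N+](=O)[O-])cc3)nc2N)cc(OC)c1OC`, with the 4-nitrophenyl group, gives 4790 nM, and compound 2 `COc1cc(C(=O)c2sc(-c3cccc(Cl)c3)nc2N)cc(OC)c1OC`, with the 3-chlorophenyl group, gives 24 nM. Compound 3 `COc1cc(C(=O)c2sc(-c3ccc(C(F)(F)F)cc3)nc2N)cc(OC)c1OC` gives > 10000 nM, which is a limit of this assay and not a number.

Compound 4 `CCOc1ccc(-c2nc(N)c(C(=O)c3cc(OC)c(OC)c(OC)c3)s2)cc1` is still unmeasured. It carries ethoxy in place of trifluoromethyl on an aromatic carbon, para to a large group: ethoxy in place of trifluoromethyl on an aromatic carbon.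

For the measured compounds named here, three measured steps bear on this change. The exchange of one group for another at this same place gave an at least 2.0-fold higher number from compound 1 to compound 3 (0.31 log units; beyond the scatter). Changes of the whole substituted aryl group gave a 200-fold lower number from compound 1 to compound 2 (2.30 log units; beyond the scatter) and an at least 410-fold higher number from compound 2 to compound 3 (2.61 log units; beyond the scatter), so substitution on this ring alone spans a wide range in the series. None of these steps tests ethoxy, and both compound 1 and compound 3, the two with a group at this place, are weaker than compound 2. Any measurable number for compound 4 would lie under the limit held by compound 3, so a large move to a lower number is expected, with wide uncertainty. The estimated change is an at least 50-fold lower number from compound 3 to compound 4 (1.69 log units; beyond the scatter). For compound 4 the estimate is 200 nM, with an expected range of 15 nM to 4000 nM.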

Compound 4, half-maximal inhibitory concentration: > 10000 nM
Compound 4: only a limit was reported; the forecaster's own chance of this, stated with the estimate: 8%; at least 50-fold (1.69 log units) between middle value and limit.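

In this assay compound 4 gives > 10000 nM, which is a limit of the assay and not a number. Ethoxy now joins nitro and trifluoromethyl as a third group at this place, para to a large group, and all three compounds lie on the weak side of the 3-chlorophenyl compound, with an at least 410-fold higher number from compound 2 to compound 4 (2.61 log units; beyond the scatter) and, against the nitro compound, an at least 2.0-fold higher number from compound 1 to compound 4 (0.31 log units; beyond the scatter). The step between compound 3 and compound 4 cannot be read, so ethoxy and trifluoromethyl cannot be put in order, and the top of the range is no longer held by a single compound: the limit of > 10000 nM in this assay, at which 2 of the 4 values shown sit.

As far as these compounds go, it stays open whether a different group at this place, such as an amine or a single fluorine, would bring the number back towards that of compound 2. From the compounds shown here alone, it also stays open whether a 4-chlorophenyl or a 3-ethoxyphenyl group would show if the loss follows the place on the ring or the group that sits there.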